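A Methyl on the Linker of Compound 1

The compounds below may be only part of what the source reports. "The series", "measured", "known", "first", "only" and "open" are said of these compounds alone.

Measured so far:
compound 1, `O=C(NCCCN1CCC(c2ccccc2)CC1)C(c1ccccc1)c1ccccc1`: 1100 nM
compound 2, `O=C(NCCCN1CCC(Oc2ccccc2)CC1)C(c1ccccc1)c1ccccc1`: 1400 nM

Both compounds were tested in an assay on CHO cells for inhibition of sodium channel protein type 2 subunit alpha (Rattus norvegicus); a higher number here means a weaker inhibitor, a lower number a stronger inhibitor. Compound 1 gives 1100 nM, and compound 2 gives 1400 nM; the step of a 1.3-fold higher number from compound 1 to compound 2 (0.10 log units; within the scatter) is within the scatter, so neither compound can be called the stronger inhibitor. Compound 2 differs from compound 1 only in the group on the saturated ring, phenoxy in place of phenyl, and that exchange leaves the number essentially unchanged.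

Compound 3, `CC(CNC(=O)C(c1ccccc1)c1ccccc1)CN1CCC(c2ccccc2)CC1`, keeps everything of compound 1 except one point on the chain that joins the amide to the ring nitrogen: methyl in place of hydrogen on a saturated chain carbon bound to two saturated chain carbons. Within the data shown here, no measured pair touches this chain, so the only step available, from compound 1 to compound 2, speaks to a different part of the molecule and gives no direct guide. Since that one change elsewhere produced nothing beyond the scatter, a small change on the chain is expected to do the same, with the direction unknown. For compound 3 the expected step in this assay is no change at the digits printed from compound 1 to compound 3 (within the scatter). Compound 3 is therefore estimated at 1100 nM, with a range from 400 nM to 3000 nM.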

Compound 3, half-maximal inhibitory concentration: 1500 nM
Compound 3: middle estimate off by 1.4-fold (0.13 log units), on the low side; measured number inside the range.
By their numbers in this assay, from the lowest: compounds 1, 2 and 3 (each within the scatter of the next).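

In this assay, methyl in place of hydrogen on a saturated chain carbon bound to two saturated chain carbons gives a 1.4-fold higher number from compound 1 to compound 3 (0.13 log units; within the scatter). Among these compounds, this is the first direct reading on the chain that joins the amide to the ring nitrogen, and it shows that this chain carbon can carry one extra carbon with no change that this assay can resolve, whereas the earlier pair spoke only to the group on the saturated ring. Compound 1 has now been changed in two separate places, on the ring and on the chain, and both single changes stay within the scatter, while nothing available explains why the methyl leaves the number where it is.

One small methyl at one point says little about what larger or different groups would do there, such as an ethyl, a hydroxyl or an amine, and a longer chain remains a separate question. The compounds shown also leave open how a methyl would read on the other chain carbons, or on the amide nitrogen in place of the amide hydrogen.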